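A Small Swap on the Carbonyl of a Shared Core

The source may hold more compounds than are shown below. What is called first, only, known or untested is meant among the compounds shown, and "the series" means these compounds.

Compound 1 `CC1=CC[C@H]2[C@H](CC[C@]2(C)O)C(C)(C)[C@@H]1CC[C@H]1[C@]2(C)CC[C@H](OCc3ccccc3)C(C)(C)O[C@H]2CC[C@@]1(C)O` and compound 2 `CC1=CC[C@H]2[C@H](CC[C@]2(C)O)C(C)(C)[C@@H]1CC[C@H]1[C@]2(C)CC[C@H](OC(=O)c3cccc([N+](=O)[O-])c3)C(C)(C)O[C@H]2CC[C@@]1(C)O` share one core and differ only in the group on an oxygen on a saturated carbon. In a functional assay on MDA-MB-231 cells (Homo sapiens) for antiproliferative activity, read by MTT assay, with a stated time of 72 h (on this read-out lower numbers stand for stronger inhibition and higher numbers for weaker inhibition), compound 1 gives 29100 nM and compound 2 gives 34700 nM. Going by the values given here, compound 2 therefore has no rank of its own, as its value lies within the scatter of the only other number available.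

Compound 3 `CC1=CC[C@H]2[C@H](CC[C@]2(C)O)C(C)(C)[C@@H]1CC[C@H]1[C@]2(C)CC[C@H](OC(=O)c3ccccc3Cl)C(C)(C)O[C@H]2CC[C@@]1(C)O` keeps the carbonyl of compound 2 but has 2-chlorophenyl in place of 3-nitrophenyl on that carbonyl carbon: 2-chlorophenyl in place of 3-nitrophenyl on a carbonyl carbon. Among the compounds with values here, only one measured step bears on this change: a 1.2-fold higher number from compound 1 to compound 2 (0.08 log units; within the scatter), with (3-nitrophenyl)carbonyl replacing benzyl. Within the data shown here, that step is small, but it is only indirect evidence, since no measured pair varies the aromatic group on the carbonyl carbon alone. The data therefore point in neither direction, and no change beyond the scatter is expected in this assay. The estimated size of the change is a 1.2-fold lower number from compound 2 to compound 3 (0.06 log units; within the scatter). For compound 3 the expected value is 30000 nM, with an estimated range from 14000 nM to 60000 nM.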

Compound 3, half-maximal inhibitory concentration: 24300 nM
For compound 3 the middle estimate is 1.2-fold (0.09 log units) above the measured one; measured number inside the range.
By their numbers in this assay, from the lowest: compounds 3, 1 and 2 (each within the scatter of the next).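

Going by these compounds alone, replacing 3-nitrophenyl with 2-chlorophenyl on the carbonyl carbon gives, in this assay, a 1.4-fold lower number from compound 2 to compound 3 (0.15 log units; within the scatter) as the first direct reading of the aromatic group alone, with the carbonyl kept in place. Compared with the benzyl group on the same oxygen, (2-chlorophenyl)carbonyl gives a 1.2-fold lower number from compound 1 to compound 3 (0.08 log units; within the scatter) and this completes the set: benzyl, (3-nitrophenyl)carbonyl and (2-chlorophenyl)carbonyl all read alike within the scatter, even though the nitro-bearing group and the chlorine-bearing group differ in heavy atoms and hydrogen-bond acceptors. No measurement is available that offers a reason for this sameness.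

All three compounds carry a six-membered aromatic ring of carbon on this oxygen, so this flat result says nothing yet about a group without such a ring, such as a simple acetyl, a longer alkyl chain, or a chain ending in an amine or a carboxylic acid. As far as these compounds go, how 3-chlorophenyl or a plain phenyl on the same carbonyl carbon would read also stays open, as does whether any change at this oxygen can move the number beyond the scatter.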